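Fluoro to Trifluoromethyl on an Aryl Piperazine Succinimide

The source may hold more compounds than are shown below. What is called first, only, known or untested is meant among the compounds shown, and "the series" means these compounds.

Three compounds were measured in a functional assay on the whole organism (strain Swiss) with Mus musculus as the target, in the maximal electroshock model, with a stated time of 1 h, at a dose of 300 mg/kg by the intraperitoneal route; on this read-out higher numbers stand for a stronger effect at the one dose given and lower numbers for a weaker effect:
compound 1 `CCC(C(=O)N1CCN(c2cccc(F)c2)CC1)N1C(=O)CCC1=O` gives 75%;
compound 2 `CC(C(=O)N1CCN(c2ccc(C(F)(F)F)cc2)CC1)N1C(=O)CCC1=O` gives 0%;
compound 3 `CC(C(=O)N1CCN(c2ccc(F)cc2)CC1)N1C(=O)CCC1=O` gives 25%.

Compound 1 stands highest of the three in this assay, with compound 3 nearest and compound 2 furthest. How the cores of compound 1 and compound 3 differ is not broken down here.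

From compound 3 to compound 2 the change is trifluoromethyl in place of fluoro on an aromatic carbon, and in this assay it gave a number 25 percentage points lower from compound 3 to compound 2 (beyond the scatter).

Compound 4 `CCC(C(=O)N1CCN(c2cccc(C(F)(F)F)c2)CC1)N1C(=O)CCC1=O` has not yet been measured. From compound 1 to compound 4 the change is trifluoromethyl in place of fluoro on an aromatic carbon, the same kind of change, though here the place is meta to a large group where in the earlier pair it is para to a large group.

Compound 4 is expected to fall in this assay by a number 35 percentage points lower from compound 1 to compound 4 (beyond the scatter), because compound 3 to compound 2 gave a number 25 percentage points lower from compound 3 to compound 2 (beyond the scatter) and compound 1 starts from 75%. Compound 4 is thus estimated at 40%, between 10% and 75%.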

Compound 4, a percentage reported as activity, at one dose (the size of the read-out at that dose, not a potency): 100%
For compound 4 the middle estimate is 60 percentage points below the measured one; the measured number lies above the stated range.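

In this assay, trifluoromethyl in place of fluoro gave a number 25 percentage points higher from compound 1 to compound 4 (beyond the scatter), so the change did not carry over from one core to the other with the same direction, and its effect in this series cannot be taken as fixed: the same change on two cores in this assay, a number 25 percentage points lower (beyond the scatter) from compound 3 to compound 2 and a number 25 percentage points higher (beyond the scatter) from compound 1 to compound 4, 50 percentage points apart, beyond the scatter of two such steps

The two pairs differ both in their cores and in where the change sits on the aromatic ring, and with a single pair for each, the data cannot say which of these accounts for the reversal. Nor do they show which way the change would go on a further core.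

The compounds shown leave open how a chloro or a methoxy group at the same place would read in this assay. They also leave open whether a longer chain on the core would alter the result.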